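One Methyl Removed: What Compound 3 Might Show

The source may hold more compounds than are shown below. What is called first, only, known or untested is meant among the compounds shown, and "the series" means these compounds.

Two compounds have been measured so far:

Compound 1 `N/C(=N\NC(=S)N1CCSCC1)c1ccccn1`: 72.6%
Compound 2 `Cc1ccnc(/C(N)=N/NC(=S)N2CCCCC2)c1`: 61.7%

In a functional assay on MCF7 cells (Homo sapiens) for cytotoxicity, read by MTT assay, with a stated time of 72 h, tested at 30 uM (on this read-out higher numbers stand for more inhibition of growth at the one concentration tested and lower numbers for less inhibition of growth), compound 1 gives 72.6%, while compound 2 gives 61.7%. Compound 2 therefore stands lowest of the two numbers; the nearest value, that of compound 1, lies higher by a margin beyond the usual scatter. Within the data shown here, compound 1 and compound 2 differ in more than one place, so no single step between them can be read from their values; they show only that compound 1 inhibits growth more than compound 2 at the concentration tested.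

Compound 3 `N/C(=N\NC(=S)N1CCCCC1)c1ccccn1` has not yet been measured. It differs from compound 2 as follows: hydrogen in place of methyl on an aromatic carbon. The change is small, a single carbon lost from the ring that carries the large group. Among the measured compounds shown here, with no measured pair showing this change, the expectation rests only on its size: a step from compound 2 to compound 3 of a number 3.3 percentage points higher from compound 2 to compound 3 (within the scatter) is expected, most likely within the scatter, with a slight lean upward. Compound 3 is estimated at 65%, with a range from 47% to 83%.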

Compound 3, percent growth inhibition at one concentration: 69.3%
Estimate against measurement, compound 3: 4.3 percentage points below, and the stated range covers the measured number.
By their numbers in this assay, from the lowest: compounds 2, 3 and 1 (each within the scatter of the next, the first and the last beyond it).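

Among these compounds, compound 3 supplies the first two pairs that differ in one place in this assay. Hydrogen in place of methyl on an aromatic carbon, opposite the ring nitrogen, gives a step of [ a number 7.6 percentage points higher from compound 2 to compound 3 (within the scatter) ], so the loss of this methyl is not shown to alter growth inhibition at this position, while piperidin-1-yl in place of thiomorpholin-4-yl on the thiocarbonyl carbon gives a step of [ a number 3.3 percentage points lower from compound 1 to compound 3 (within the scatter) ], so this read-out does not tell these two groups apart at the one concentration tested. No measurement among the data bears on either step, and what lies behind them remains unexplained.

The compounds shown leave open whether another group on that aromatic carbon, such as methoxy, chlorine or an amine, would shift the number beyond the scatter. Also open, going by these compounds, is whether morpholin-4-yl or an open-chain diethylamino group on the thiocarbonyl carbon would separate from piperidin-1-yl and thiomorpholin-4-yl.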